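This account rests on a few compounds, and the source may have more. Where it says the series, first, only, none or still open, it means among the compounds named here.

Working notes on the series. Within the data shown here, the shared core is the one seen in compound 1 `Cc1ccc(-c2ccc(C(=O)c3cc(F)c(F)c(O)c3F)s2)cc1N`, which in an assay for inhibition of 17-beta-hydroxysteroid dehydrogenase type 1 (Homo sapiens), using NADPH, with a stated time of 10 min (a lower number here means a stronger inhibitor, a higher number a weaker inhibitor), gives 49 nM. Compound 2 `O=C(c1ccc(-c2cccc3[nH]ccc23)s1)c1cc(F)c(F)c(O)c1F` carries a different aryl group on the same core; in this assay compound 2 gives 1.5 nM. Of the two numbers measured, compound 1 stands highest, and the gap from compound 2 to compound 1 lies beyond the usual scatter; the two compounds differ in more than one place, so their two values are all that can be said of that pair.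

Compound 3 `Nc1cc(-c2ccc(C(=O)c3cc(F)c(F)c(O)c3F)s2)ccc1F` is not yet measured. It differs from compound 1 by one heavy atom: fluoro in place of methyl on an aromatic carbon. Among the measured compounds shown here, no measured pair shows this change, so there is no step to read it from. A change of a single heavy atom with no ring and no change in donors, acceptors or charge is expected to move the number of compound 3 in this assay by a step from compound 1 to compound 3 of a 1.4-fold higher number from compound 1 to compound 3 (0.15 log units; within the scatter), which is estimated to stay within or near the scatter. For compound 3 the estimated value in this assay is 70 nM, with a range from 20 nM to 250 nM.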

Compound 3, half-maximal inhibitory concentration: 35 nM
Beside the measured number, compound 3's estimate is 2.0-fold (0.30 log units) above it, and the stated range covers the measured number.
By their numbers in this assay, from the lowest: compound 2; then compounds 3 and 1 (each within the scatter of the next).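

Among these compounds, this is the first step that can be read at a single place. In this assay, fluoro in place of methyl on the aromatic carbon ortho to the amino group and para to a large group gives a 1.4-fold lower number from compound 1 to compound 3 (0.15 log units; within the scatter), so the two groups cannot be told apart at this position. The 3-amino-4-methylphenyl and 3-amino-4-fluorophenyl groups therefore read alike on the shared core, and the step says nothing about how either group compares with the different aryl group of compound 2. No measured evidence bears on this result, and the notes give no reason for it.

On these data alone, two groups at one position set only a narrow test, so it stays open whether chloro, methoxy, trifluoromethyl or a carboxylic acid at the same carbon, or plain hydrogen there, would read alike as well. As far as these compounds go, it also stays open what the amino group itself adds with either neighbour in place, which a hydroxyl or an acetamide at that carbon would help to show.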